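The source may report more compounds than this note shows. Statements on the series, on what has been measured and on what is new or still open speak of the compounds shown alone.

In an ADME assay on L929 cells (Mus musculus) for cytotoxicity, read by resazurin assay, with a stated time of 48 h (a higher number here means that more compound is tolerated, a lower number that less compound is tolerated), compound 3 (`O=[N+]([O-])c1ccc2nn(Cc3ccccc3)c(OCCBr)c2c1`) gives > 256000 nM as its reading, which is a limit and not a number. Compound 2 (`CNC(=O)CCCn1c2ccc([N+](=O)[O-])cc2c(=O)n1Cc1ccccc1`) gives > 256000 nM as its reading, likewise a limit. Compound 3 thus stands at the limit of > 256000 nM in this assay, at which 2 of the 3 values shown sit, and offers no exact starting point. Compound 4 (`COC(=O)COc1c2cc([N+](=O)[O-])ccc2nn1Cc1ccccc1`) has methoxycarbonyl in place of bromomethyl on a saturated chain carbon bound to an oxygen on an aromatic ring. For the measured compounds named here, the one measured step involving this group is an at least 1.9-fold higher number from compound 1 to compound 2 (0.29 log units; that floor lies within the scatter) and it lies elsewhere, on a saturated chain carbon bound to an aromatic nitrogen. Its floor lies within the scatter. Compound 1 (`COC(=O)Cn1c2ccc([N+](=O)[O-])cc2c(=O)n1Cc1ccccc1`), the measured compound carrying methoxycarbonyl, gives 129000 nM as a true number, so a modest step toward a lower number is expected in this assay, possibly none beyond the scatter. The estimated change is an at least 1.8-fold lower number from compound 3 to compound 4 (0.26 log units; that floor lies within the scatter) and no more than that is expected. For compound 4 the estimated value is 140000 nM with an expected range from 60000 nM to 280000 nM as its span.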

Compound 4, concentration lethal to 50% of the cells: > 256000 nM
Compound 4: only a limit was reported; the forecaster's own chance of this, stated with the estimate: 30%; at least 1.8-fold (0.26 log units) between middle value and limit.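

In this assay, for the compounds shown here, compound 4 gives > 256000 nM, a limit and not a number, and compound 3 also stands at a limit, so no step between compound 3 and compound 4 can be read. As far as these compounds go, whether methoxycarbonyl in place of bromomethyl changes the reading at all stays open.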